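The source may report more compounds than this note shows. Statements on the series, on what has been measured and on what is new or still open speak of the compounds shown alone.

Measured so far in a functional assay on MGC-803 cells (Homo sapiens) for cytotoxicity, read by MTT assay, with a stated time of 72 h; a lower number here means a stronger inhibitor, a higher number a weaker inhibitor:

Compound 1 (`FC(F)(F)c1ccc(CSc2nc(Nc3ccccc3)c3ccccc3n2)cc1`) gives 22200 nM.
Compound 2 (`FC(F)(F)c1ccc(CSc2nc(Nc3ccccc3C(F)(F)F)c3ccccc3n2)cc1`) reaches only the assay limit of > 50000 nM.
Compound 3 (`COc1ccc(Nc2nc(SCc3ccc(C(F)(F)F)cc3)nc3ccccc23)cc1`) gives 13800 nM.

All three share a core and differ only in the ring attached to the amine nitrogen. Compound 3 has the lowest of the two numbers that are real values, but its nearest neighbour is compound 1, and the step of a 1.6-fold lower number from compound 1 to compound 3 (0.21 log units; within the scatter) is too small to count as a real difference. Compound 2 stands apart only as a limit, (the limit of > 50000 nM in this assay, at which 1 of the 3 values shown sits), so the step of an at least 2.2-fold higher number from compound 1 to compound 2 (0.35 log units; beyond the scatter) and the step of an at least 3.6-fold lower number from compound 2 to compound 3 (0.55 log units; beyond the scatter) are known in direction but not in full size.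

Compound 4 (`COc1ccc(Nc2nc(SCc3ccc(C(F)(F)F)cc3)nc3ccccc23)cc1OC`) is the next one to be measured. It differs from compound 3 by methoxy in place of hydrogen on an aromatic carbon. Among the compounds with values here, the only measured step of the same kind, a methoxy in place of a hydrogen on the amine-bearing ring, is a 1.6-fold lower number from compound 1 to compound 3 (0.21 log units; within the scatter), which stayed within the scatter. On that basis no step beyond the scatter is expected for compound 4 in this assay, neither up nor down.

Compound 4 is therefore estimated at 12000 nM, with a likely range from 5000 nM to 30000 nM, which means an expected step of a 1.2-fold lower number from compound 3 to compound 4 (0.06 log units; within the scatter).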

Compound 4, half-maximal inhibitory concentration: 16300 nM
Estimate against measurement, compound 4: 1.4-fold (0.13 log units) below; low and high end bracket the measured number.
By their numbers in this assay, from the lowest: compounds 3, 4 and 1 (each within the scatter of the next). At a limit, above all of these: compound 2.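

Adding a second methoxy, which turns 4-methoxyphenyl into 3,4-dimethoxyphenyl and sits ortho to the existing methoxy group, gives a 1.2-fold higher number from compound 3 to compound 4 (0.07 log units; within the scatter) in this assay and so produces no step that can be told apart from the scatter. Compared with the plain phenyl ring, the two methoxy groups together give a 1.4-fold lower number from compound 1 to compound 4 (0.13 log units; within the scatter) and likewise stay within the scatter, so neither the first nor the second methoxy has a readable effect here. The only step beyond the scatter is an at least 3.0-fold lower number from compound 2 to compound 4 (0.48 log units; beyond the scatter) and it is known in direction but not in full size, since compound 2 is a limit of the assay: the limit of > 50000 nM in this assay, at which 1 of the 4 values shown sits.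

The compounds shown carry only methoxy or trifluoromethyl on this ring, so it remains open whether an amine, a carboxylic acid or a longer chain such as ethoxy at the same position would move the number beyond the scatter. From the compounds shown here alone, it also remains open how a methoxy at this position would behave alone, on a ring without the 4-methoxy group.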